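Shifting the Alkyne Aryl Group from Amino to Methoxy

A few compounds are considered here, and "the series" means these few. Any claim that something is new, unique, unknown or untested is made for them only; others in the source may bear on it.

Compound 3 `COC(=O)c1sc2cc(C#Cc3ccc(N)cc3)cnc2c1N` gives the lowest number of the two numbers reported in a functional assay on A375-C5 cells (Homo sapiens) for inhibition, read by sulforhodamine B assay, with a stated time of 48 h (on this read-out lower numbers stand for stronger inhibition of growth and higher numbers for weaker inhibition of growth), namely 4800 nM. Its nearest neighbour is compound 2 `COC(=O)c1sc2cc(C#Cc3cccc(N)c3)cnc2c1N`, which in this assay gives 11600 nM; that gap is a 2.4-fold lower number from compound 2 to compound 3 (0.38 log units; beyond the scatter). Compound 1 `COC(=O)c1sc2cc(C#Cc3ccc(OC)cc3)cnc2c1N` reaches only the limit of this assay, > 37500 nM, which is a limit and not a number (the limit of > 37500 nM in this assay, at which 1 of the 3 values shown sits). From compound 1 the change to the amino analogue is an at least 7.8-fold lower number from compound 1 to compound 3 (0.89 log units; beyond the scatter), and to the other amino analogue an at least 3.2-fold lower number from compound 1 to compound 2 (0.50 log units; beyond the scatter).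

Compound 4 `COC(=O)c1sc2cc(C#Cc3ccccc3OC)cnc2c1N` has not yet been measured in this assay. The change from compound 3 is 2-methoxyphenyl in place of 4-aminophenyl on a triple-bonded carbon. Among the compounds with values here, two measured steps bear on it: the exchange of methoxy for amino on the same ring, an at least 7.8-fold lower number from compound 1 to compound 3 (0.89 log units; beyond the scatter), and the move of the amino group between ring positions, a 2.4-fold lower number from compound 2 to compound 3 (0.38 log units; beyond the scatter). Both point the same way, towards a larger number, and the first of them is the larger. The step of a 6.3-fold higher number from compound 3 to compound 4 (0.80 log units; beyond the scatter) is therefore expected to be clearly beyond the scatter and towards weaker inhibition of growth. For compound 4 the estimate in this assay is 30000 nM, expected to fall between 9000 nM and 100000 nM, with a real chance that only a limit is returned.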

Compound 4, concentration for 50% growth inhibition: > 47300 nM
Compound 4 ended at the assay's limit; the forecaster's own chance of this, stated with the estimate: 45%; middle value at least 1.5-fold (0.19 log units) away from the limit.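

In this assay, the change to 2-methoxyphenyl on the triple-bonded carbon is unfavourable from either aminophenyl compound, giving an at least 9.8-fold higher number from compound 3 to compound 4 (0.99 log units; beyond the scatter) and an at least 4.0-fold higher number from compound 2 to compound 4 (0.61 log units; beyond the scatter), so growth inhibition weakens from both amino starting points. Compound 4 gives a limit and not a number, so a second methoxyphenyl placement also fails to give a measurable value, and among the compounds shown only the two aminophenyl compounds reach one: the limit of > 47300 nM in this assay, at which 1 of the 4 values shown sits. Compound 1 also gives a limit and not a number, and the step from it to compound 4 cannot be read, so the two methoxyphenyl compounds cannot be ranked against each other: the limit of > 37500 nM in this assay, at which 1 of the 4 values shown sits.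

The change from compound 3 to compound 4 alters both the group and its place on the ring at once, so the share of each in the loss remains unresolved. Also open, from the compounds shown here alone, is how groups such as a hydroxyl, a dimethylamino group or a carboxylic acid would compare with the amine on this ring in this assay.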